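The source may hold more compounds than are shown below. What is called first, only, known or untested is meant among the compounds shown, and "the series" means these compounds.

In a functional assay on the whole organism (strain Wistar) for inhibition, with Rattus norvegicus as the target, read by paw edema, with stated times of 30 min and 3 h, at a dose of 100 mg/kg by the oral route (on this read-out lower numbers stand for less inhibition and higher numbers for more inhibition at the one dose given (going by the name of the read-out)), three compounds of a shared core have so far been measured. Compound 1 `COc1cc(C(N)=O)nn1-c1ccccc1` gives 34.3%. Compound 2 `COc1cc(C(=O)N2CCCC2)nn1-c1ccccc1` gives 29.2%; the change is a number 5.1 percentage points lower from compound 1 to compound 2 (within the scatter). Compound 3 `CCCCOc1cc(C(N)=O)nn1-c1ccccc1` gives 26.5%; the change is a number 7.8 percentage points lower from compound 1 to compound 3 (within the scatter). Compound 3 thus holds the lowest of the three numbers, yet its gaps to compound 2 and to compound 1 both lie within the scatter, so no order among the three can be read from them.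

Among the compounds with values here, compound 4 `CCCCOc1cc(C(=O)NCCCN(C)C)nn1-c1ccccc1` has not yet been measured. 3-(dimethylamino)propyl in place of hydrogen on an amide-type nitrogen Of the measured steps, only the one from compound 1 to compound 2 touches the same place, the substituent on the amide-type nitrogen, and that step stayed within the scatter. Nothing measured points to a shift beyond the scatter in either direction. On that basis compound 4 is expected to give 27%, between 12% and 42%. The step of a number 0.5 percentage points higher from compound 3 to compound 4 (within the scatter) is therefore expected to stay within the scatter.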

Compound 4, a percentage reported as inhibition, in the whole organism at one dose (the size of the read-out at that dose, not a potency): 29.8%
Estimate against measurement, compound 4: 2.8 percentage points below; low and high end bracket the measured number.
By their numbers in this assay, from the lowest: compounds 3, 2, 4 and 1 (each within the scatter of the next).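

In this assay, 3-(dimethylamino)propyl in place of hydrogen on an amide-type nitrogen gives a number 3.3 percentage points higher from compound 3 to compound 4 (within the scatter), so an open chain of 6 heavy atoms, with no ring, can stand at this nitrogen without a change that can be read at this one dose. The earlier change at the same amide group, pyrrolidin-1-yl in place of amino on a carbonyl carbon, gave a number 5.1 percentage points lower from compound 1 to compound 2 (within the scatter), so neither substitution there has moved the number beyond the scatter, on either of the two parent compounds. Nothing available gives a cause for this result.

Going by these compounds, whether a longer chain, or a carboxylic acid or a primary amine at the end of the chain, would move the number beyond the scatter stays open. Also open, on these data alone, is whether 3-(dimethylamino)propyl would give a similar step on compound 1.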